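A few compounds are considered here, and "the series" means these few. Any claim that something is new, unique, unknown or untested is made for them only; others in the source may bear on it.

Measured compounds in an in vitro functional assay on HEK285-7 cells for antagonist activity at prostaglandin D2 receptor 2 (Homo sapiens), read by BRET and beta-arrestin recruitment; on this read-out higher numbers stand for larger maximal responses and lower numbers for smaller maximal responses:

- compound 1, `O=C(O)Cc1sc(C(c2ccccc2)c2ccccc2)nc1-c1ccc(F)cc1`: 80%
- compound 2, `O=C(O)Cc1sc(C(c2ccccc2)c2ccc(Cl)cc2)nc1-c1ccc(Cl)cc1`: 80%
- compound 3, `O=C(O)Cc1sc(Cc2ccccc2)nc1-c1ccc(Cl)cc1`: 50%

Compound 2 stands level with compound 1 at the digits shown; together they give the highest of the three numbers. Within the data shown here, compound 3 sits furthest from compound 2, and the one step that differs in a single place, a number 30 percentage points lower from compound 2 to compound 3 (beyond the scatter), is the only measured step in this set; it concerns hydrogen in place of 4-chlorophenyl on a saturated chain carbon bound to two aromatic carbons and so lies at a different part of the molecule from the change considered here.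

Compound 4, `O=C(O)Cc1sc(C(c2ccccc2)c2ccc(Cl)cc2)nc1-c1ccc(F)cc1`, is not yet measured. It differs from compound 2 by fluoro in place of chloro on an aromatic carbon of a six-membered aromatic ring of carbon only, para to a large group. Among the measured compounds shown here, no single-place step covers this swap. Compounds 1 and 2 differ in two places, one of them this same 4-chlorophenyl to 4-fluorophenyl exchange, and their two values are identical at the digits shown; that is the only hint available, and it points to no change beyond the scatter.

Compound 4 is therefore estimated at 80%, within 65% to 92%. The expected step is no change at the digits printed from compound 2 to compound 4 (within the scatter), none beyond the scatter.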

Compound 4, largest response reached (reported as efficacy), in percent of the reference or control that the assay uses: 80%
Estimate against measurement, compound 4: no gap at the digits printed; the range from low to high includes it.
By their numbers in this assay, from the lowest: compound 3; then compounds 1, 2 and 4 (each within the scatter of the next).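

In this assay, among these compounds, fluoro in place of chloro on an aromatic carbon of a six-membered aromatic ring of carbon only, para to a large group, gives no change at the digits printed from compound 2 to compound 4 (within the scatter) and so reads this exchange on its own for the first time, free of any second difference. Chloro in place of hydrogen on an aromatic carbon gives no change at the digits printed from compound 1 to compound 4 (within the scatter) as well, so the equal numbers of compound 1 and compound 2 come from two single changes that each leave the read-out unmoved, not from two steps beyond the scatter that cancel. Nothing on hand gives a reason for either result.

On these data alone, only the two halogens have been compared at this place, so it remains open whether methoxy, trifluoromethyl, nitrile or an amine there would hold the maximal response as well. Also open, as far as these compounds go, is whether hydrogen in place of 4-chlorophenyl on the saturated chain carbon would cost as much with 4-fluorophenyl on the shared core as it does with 4-chlorophenyl.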